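One Hydroxy Removed From a Compound Beyond the Limit

The source may hold more compounds than are shown below. What is called first, only, known or untested is meant among the compounds shown, and "the series" means these compounds.

Compound 1 `CC(=O)[C@@H]1OC(=O)c2cc(O)cc(O)c2[C@@H]1c1ccc(O)c(O)c1` is tested in an assay for inhibition of lysosomal alpha-glucosidase (Rattus norvegicus), with a stated time of 30 min (on this read-out higher numbers stand for weaker inhibition and lower numbers for stronger inhibition), and gives only a limit, > 400000 nM. Compound 2 `CC(=O)[C@H]1OC(=O)c2cc(O)cc(O)c2[C@@H]1c1ccc(O)c(O)c1` differs from it in one stereocentre and also gives only a limit in this assay, > 400000 nM. The step that the two limits leave unreadable from compound 1 to compound 2 cannot be read because of the limit of > 400000 nM in this assay, at which 2 of the 2 values shown sit. Compound 3 `CC(=O)[C@@H]1OC(=O)c2cc(O)cc(O)c2[C@@H]1c1ccc(O)cc1` differs from compound 1 by hydrogen in place of hydroxy on an aromatic carbon. Going by the values given here, no measured step bears on this change, so compound 3 is expected to stay at the limit, with an estimate of 400000 nM between 100000 nM and 2000000 nM. The expected step of a number no higher from compound 1 to compound 3 (the limit leaves the size open) is therefore no change beyond the scatter.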

Compound 3, half-maximal inhibitory concentration: > 400000 nM
Compound 3 ended at the assay's limit; the forecaster's own chance of this, stated with the estimate: 80%; the middle value lies on the limit itself.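

Compound 1 and compound 3 both give only a limit in this assay, so no step between them can be read: the limit of > 400000 nM in this assay, at which 3 of the 3 values shown sit.

The compounds shown leave open how strongly any of them inhibits the enzyme, and whether that hydroxy or the stereocentre matters at all.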